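Swapping the Aryl Group on the Saturated Ring Carbon

The source may hold more compounds than are shown below. What is called first, only, known or untested is meant among the compounds shown, and "the series" means these compounds.

Three compounds have been measured so far:
compound 1 `COc1ccc(/C=N/NC(=O)c2cc(OC)c(OC)c(OC)c2)c(OC)c1` gives 3.6%
compound 2 `COc1cc(C2=NN(C(C)=O)C(c3ccc(F)c(F)c3)O2)cc(OC)c1OC` gives 21.6%
compound 3 `COc1cc(C(=O)N/N=C/c2cccc(C(F)(F)F)c2)cc(OC)c1OC` gives 33.8%

In a functional assay on BGC-823 cells (Homo sapiens) for antiproliferative activity, read by MTT assay, tested at 5 uM (a higher number here means a stronger effect of the compound at the concentration tested, a lower number a weaker effect), compound 2 stands second highest of the three numbers. Its nearest neighbour is compound 3, whose value lies higher by an amount beyond the scatter; its furthest is compound 1, whose value lies lower by an amount beyond the scatter. Among the compounds with values here, none of the three measured compounds differs from another in a single place, so no step of one change has yet been seen.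

Compound 4 `COc1ccc(OC)c(C2OC(c3cc(OC)c(OC)c(OC)c3)=NN2C(C)=O)c1` is the next compound to be measured. It keeps the core of compound 2 and differs from it in one place: 2,5-dimethoxyphenyl in place of 3,4-difluorophenyl on a saturated ring carbon. Compound 1 also carries a dimethoxyphenyl group, though on a different core, and in this assay compound 1 gives 3.6%, the lowest of the three. Within the data shown here, the data give no measured step for a change of this kind, so the direction is open. The step of a number 4.6 percentage points lower from compound 2 to compound 4 (within the scatter) is expected to be small, within the scatter or slightly downward. Compound 4 is therefore expected to give 17% in this assay, with a likely range from 4% to 32%.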

Compound 4, a percentage reported as inhibition, at one concentration (the size of the read-out at that concentration, not a potency): 18.2%
For compound 4 the middle estimate is 1.2 percentage points below the measured one; low and high end bracket the measured number.
By their numbers in this assay, from the lowest: compound 1; then compounds 4 and 2 (each within the scatter of the next); then compound 3.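

Within the data shown here, this is the first step of one change, and in this assay it reads a number 3.4 percentage points lower from compound 2 to compound 4 (within the scatter) on the shared core. At the saturated ring carbon, next to the ring oxygen and the ring atom that bears an acetyl group, the exchange of 3,4-difluorophenyl for 2,5-dimethoxyphenyl replaces fluorine with oxygen, raises the group from 8 to 10 heavy atoms and brings 2 hydrogen-bond acceptors where there were 0, yet this pair of aryl groups shows no difference beyond the scatter at the single concentration tested. No measurement among the compounds shown bears on why this step is as small as it is.

Only these two aryl groups are shown at this position, both with the same acetyl group on the ring nitrogen, so the step says nothing yet about how far the position tolerates change in general. On these data alone, whether an aryl group carrying an amine or a carboxylic acid, a longer chain in place of the aryl group, or a longer acyl chain in place of the acetyl group would give a step beyond the scatter remains open.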